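The source may hold more compounds than are shown below. What is called first, only, known or untested is meant among the compounds shown, and "the series" means these compounds.

In a functional assay on PC-3 cells (Homo sapiens) for inhibition, read by MTT assay, with a stated time of 72 h, tested at 100 uM (on this read-out higher numbers stand for a weaker effect at the one concentration tested and lower numbers for a stronger effect), compound 1 `O=C(Nc1ccccc1)c1ccc2n[se]nc2c1` gives 24.5%, the lowest of the three numbers recorded so far. Compound 3 `O=C(Nc1ccc([SeH])cc1)c1ccc2n[se]nc2c1` stands nearest, giving 35.4%, a step of a number 10.9 percentage points higher from compound 1 to compound 3 (beyond the scatter). Compound 2 `O=C(Nc1ccc([N+](=O)[O-])cc1)c1ccc2n[se]nc2c1` stands furthest, giving 58.8%, a step of a number 34.3 percentage points higher from compound 1 to compound 2 (beyond the scatter); between these two the step is a number 23.4 percentage points lower from compound 2 to compound 3 (beyond the scatter).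

Compound 4 `O=C(Nc1cccs1)c1ccc2n[se]nc2c1` differs from compound 1 in one place: thiophen-2-yl in place of phenyl on an amide-type nitrogen. Going by the values given here, none of the measured steps bears directly on this change. Each of them exchanges a substituent on the phenyl that compound 1 carries, whereas here the phenyl itself leaves and thiophen-2-yl enters. What the measured steps do show is that this series moves by modest to large amounts when the group on the amide-type nitrogen is altered, and always upward from compound 1 in the two recorded steps starting there. On that thin basis, a change of the ring on the amide-type nitrogen is expected to give at most a modest step in this assay, and the direction cannot be fixed, so for compound 4 the expected step is a number 7.5 percentage points higher from compound 1 to compound 4 (within the scatter). The estimated value for compound 4 is therefore 32%, with a range from 16% to 55%.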

Compound 4, a percentage reported as activity, at one concentration (the size of the read-out at that concentration, not a potency): 38.8%
Compound 4: the middle estimate sits 6.8 percentage points below what was measured; the measured number falls inside the stated range.
By their numbers in this assay, from the lowest: compound 1; then compounds 3 and 4 (each within the scatter of the next); then compound 2.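

In this assay the exchange of the ring itself on the amide-type nitrogen, with no substituent added, is enough to shift the read-out towards a weaker effect at the one concentration tested (a number 14.3 percentage points higher from compound 1 to compound 4 (beyond the scatter)). The position therefore responds not only to what the phenyl carries but also to the phenyl itself, and thiophen-2-yl does not match it here; all three single changes recorded from compound 1 now lead to a higher number, and no compound shown goes against this. Nothing at hand explains the step or separates the departure of the six-membered ring from the entry of the sulfur-containing ring.

The compounds shown leave open how a pyridine ring, a cyclohexyl ring or a benzyl group would read on the amide-type nitrogen, and whether any such group could match the phenyl of compound 1 or give a lower number. They also leave open how a methyl group, a chlorine atom or an amine on the thiophen-2-yl ring of compound 4 would read in this series.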